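From pyrrolidin-1-yl to (4-methoxyphenyl)amino

A few compounds are considered here, and "the series" means these few. Any claim that something is new, unique, unknown or untested is made for them only; others in the source may bear on it.

Values from a functional assay on MCF7 cells (Homo sapiens) for inhibition, read by sulforhodamine B assay (a lower number here means a stronger inhibitor, a higher number a weaker inhibitor), follow, and each one is a limit:

- compound 1 `O=C1C(Nc2ccccc2F)=CC(=O)c2c1nc1n2[C@H]2OC[C@@H](O)[C@H]2OC1` gives > 4000 nM
- compound 2 `O=C1C(Nc2ccccc2)=CC(=O)c2c1nc1n2[C@H]2OC[C@@H](O)[C@H]2OC1` gives > 4000 nM
- compound 3 `O=C1C(N2CCCC2)=CC(=O)c2c1nc1n2[C@H]2OC[C@@H](O)[C@H]2OC1` gives > 16000 nM

Compound 3 has only a limit and no number, and its entry is the limit of > 16000 nM in this assay, at which 1 of the 3 values shown sits. The other two compounds stand at the limit of > 4000 nM in this assay, at which 2 of the 3 values shown sit.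

The change to unmeasured compound 4 `COc1ccc(NC2=CC(=O)c3c(nc4n3[C@H]3OC[C@@H](O)[C@H]3OC4)C2=O)cc1` is (4-methoxyphenyl)amino in place of pyrrolidin-1-yl on a double-bonded ring carbon, placing (4-methoxyphenyl)amino where pyrrolidin-1-yl stood on a double-bonded ring carbon.

Among the compounds with values here, three measured steps bear on this change. The closest is a step that the two limits leave unreadable from compound 2 to compound 3, a similar swap run the other way, with anilino as the partner group. Next comes a step that the two limits leave unreadable from compound 1 to compound 3, which involves (2-fluorophenyl)amino instead. The third is a step that the two limits leave unreadable from compound 1 to compound 2, which alters only the aromatic ring's substituent. Within the data shown here, none has a readable size, so no measured step fixes the size or direction expected here.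

Compound 2, with its anilino group and its limit of > 4000 nM, is the nearest guide, so another limit is the likeliest result for compound 4. If a number does appear in this assay, the expected result is an at least 2.0-fold lower number from compound 3 to compound 4 (0.30 log units; that floor lies within the scatter), a loose expectation of a step toward lower numbers. The estimate for compound 4 is 8000 nM, with an expected range from 2500 nM to 25000 nM.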

Compound 4, half-maximal inhibitory concentration: 4470 nM
The estimate for compound 4 lay 1.8-fold (0.25 log units) above the measured number; the range from low to high includes it.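

Among the compounds shown, compound 4 is the only one with an actual number rather than a limit in this assay, so this double-bonded ring carbon can carry a group that gives a measurable result. Placing (4-methoxyphenyl)amino where pyrrolidin-1-yl stood gives an at least 3.5-fold lower number from compound 3 to compound 4 (0.55 log units; beyond the scatter), the only readable step in the set, and it shows that the change at this position moves the result toward stronger inhibition. This step gives only a minimum size, not an exact one, as compound 3 has a limit and no number: the limit of > 16000 nM in this assay, at which 1 of the 4 values shown sits.

Going by these compounds, the steps from compound 1 and from compound 2 to compound 4 cannot be read, so it remains open whether the methoxy group itself contributes anything beyond the plain anilino group, whose compound 2 also has only a limit: the limit of > 4000 nM in this assay, at which 2 of the 4 values shown sit. Also open is how the result would respond to other groups at this carbon, such as a 4-chloroanilino group or an open-chain amine like dimethylamino.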